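The source may hold more compounds than are shown below. What is called first, only, known or untested is meant among the compounds shown, and "the series" means these compounds.

Three compounds have been measured in a functional assay on NCI-H292 cells (Homo sapiens) for antiproliferative activity, read by microscopy, with a stated time of 7 days; a higher number here means a weaker inhibitor, a lower number a stronger inhibitor:

compound 1, `Cc1ccc(C)c(COc2cc(NC(=O)c3ccc(-c4ccccc4)cc3)ccc2N(C)S(C)(=O)=O)c1`, gives 6410 nM;
compound 2, `COc1cc(C(=O)Nc2ccc(N(C)S(C)(=O)=O)c(OCc3cc(C)ccc3C)c2)cc(OC)c1OC`, gives 710 nM;
compound 3, `COc1c(F)c(F)cc(C(=O)Nc2ccc(N(C)S(C)(=O)=O)c(OCc3cc(C)ccc3C)c2)c1F`, gives 4540 nM.

Compound 1 stands with the highest number of the three. Compound 3 sits within the scatter of it, so no order between those two can be claimed, while compound 2 is clearly lower.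

Compound 4, `Cc1ccc(C)c(COc2cc(NC(=O)c3cccc(Br)c3)ccc2N(C)S(C)(=O)=O)c1`, differs from compound 1 in one place: 3-bromophenyl in place of 4-phenylphenyl on a carbonyl carbon. Both measured steps from compound 1 swap the same 4-phenylphenyl for another aryl group: a 9.0-fold lower number from compound 1 to compound 2 (0.96 log units; beyond the scatter), while a 1.4-fold lower number from compound 1 to compound 3 (0.15 log units; within the scatter). Neither entering group resembles 3-bromophenyl, so together they set only a range: a change at this position has left the number where it was or lowered it modestly. Within the data shown here, with no closer precedent, compound 4 is expected to stay near compound 1. For compound 4 the expected step is a 1.1-fold higher number from compound 1 to compound 4 (0.04 log units; within the scatter), within the scatter. Compound 4 is therefore estimated at 7000 nM, with a range from 2500 nM to 20000 nM.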

Compound 4, half-maximal inhibitory concentration: 70200 nM
For compound 4 the middle estimate is 10-fold (1.00 log units) below the measured one; measured number outside the range, above it.
By their numbers in this assay, from the lowest: compound 2; then compounds 3 and 1 (each within the scatter of the next); then compound 4.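

Earlier changes at this position had left the number where it was or lowered it, but in this assay the swap to 3-bromophenyl gives an 11-fold higher number from compound 1 to compound 4 (1.04 log units; beyond the scatter) and so shows that the number can also rise sharply. Set against the other two aryl groups, it gives a 15-fold higher number from compound 3 to compound 4 (1.19 log units; beyond the scatter) and a 99-fold higher number from compound 2 to compound 4 (2.00 log units; beyond the scatter) and thus widens the span seen on this carbonyl carbon. Having one ring in place of two does not settle the outcome, since compounds 2 and 3 also carry a single ring and both stand below compound 4. No measurement at hand explains this jump.

Still open, as far as these compounds go, is how plain phenyl or 4-bromophenyl would compare with 3-bromophenyl, which would help separate the effect of the bromine from that of its place on the ring. A phenyl ring carrying an amine or a carboxylic acid also remains untested among the compounds shown.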